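The source may report more compounds than this note shows. Statements on the series, on what has been measured and on what is new or still open speak of the compounds shown alone.

Measured compounds in a functional assay on ACHN cells (Homo sapiens) for antiproliferative activity, read by sulforhodamine B assay; a lower number here means a stronger inhibitor of growth, a higher number a weaker inhibitor of growth:
- compound 1, `CC(C)C1CC(=O)c2s/c(=N/c3ccccc3)oc2C1`: 3080 nM
- compound 2, `CC1(C)CC(=O)c2s/c(=N/c3ccc(Cl)cc3)oc2C1`: 9810 nM
- compound 3, `CC1CC(=O)c2s/c(=N/c3ccc(Cl)cc3)oc2C1`: 12400 nM

Compound 2 gives the second highest of the three numbers in this assay. Its nearest neighbour is compound 3, reached by a 1.3-fold higher number from compound 2 to compound 3 (0.10 log units; within the scatter), a change of hydrogen in place of methyl on a saturated ring carbon. Compound 1, which differs from compound 2 at more than one place, gives the lowest number of the three.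

Compound 4, `CC1(C)CC(=O)c2s/c(=N/c3ccc(F)cc3)oc2C1`, differs from compound 2 by fluoro in place of chloro on an aromatic carbon. Within the data shown here, no measured step alters the group on the aromatic ring; the only single-place step, a 1.3-fold higher number from compound 2 to compound 3 (0.10 log units; within the scatter), touches the saturated ring and lies within the scatter. With nothing to indicate otherwise, compound 4 is expected to show no step beyond the scatter, a 1.0-fold higher number from compound 2 to compound 4 (0.01 log units; within the scatter). The estimate for compound 4 in this assay is 10000 nM, with a range from 4000 nM to 25000 nM.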

Compound 4, concentration for 50% growth inhibition: 3740 nM
Compound 4: the middle estimate sits 2.7-fold (0.43 log units) above what was measured, outside the stated range (below it).
By their numbers in this assay, from the lowest: compounds 1 and 4 (each within the scatter of the next); then compounds 2 and 3 (each within the scatter of the next).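

In this assay the group on the aromatic ring proves able to move the number beyond the scatter: fluoro in place of chloro, para to a large group, gives a modest step (a 2.6-fold lower number from compound 2 to compound 4 (0.42 log units; beyond the scatter)). Among these compounds, the one earlier single-place step (a 1.3-fold higher number from compound 2 to compound 3 (0.10 log units; within the scatter)) lies on a saturated ring carbon and stays within the scatter. No measurement here accounts for the change at this aromatic carbon. Still open, going by these compounds, is whether hydrogen, methoxy, nitrile or an amine at this place would extend the step or reverse it.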